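Methoxy-to-hydrogen step repeated on a second core

The source may hold more compounds than are shown below. What is called first, only, known or untested is meant among the compounds shown, and "the series" means these compounds.

Compound 1 `COc1cc(-c2cc(/C=C/C(=O)c3ccc(N)cc3)[nH]n2)cc(OC)c1OC` and compound 2 `COc1ccc(-c2cc(/C=C/C(=O)c3ccc(N)cc3)[nH]n2)cc1OC` share one core; compound 3 `COc1cc(C(=O)/C=C/c2cc(-c3cc(OC)c(OC)c(OC)c3)n[nH]2)cc(OC)c1OC` and compound 4 `COc1ccc(-c2cc(/C=C/C(=O)c3cc(OC)c(OC)c(OC)c3)[nH]n2)cc1OC` share another. How the core of compound 3 differs from that of compound 1 is not broken down here. In a functional assay on SK-MEL-5 cells (Homo sapiens) for cytotoxicity, read by sulforhodamine B assay, with a stated time of 48 h, tested at 100 uM (a lower number here means a stronger effect, a higher number a weaker effect of the compound at the concentration tested), compound 1 gives -94%, compound 2 gives -94% and compound 3 gives -98%. The change from compound 1 to compound 2, (hydrogen in place of methoxy on an aromatic carbon), produced no change at the digits printed from compound 1 to compound 2 (within the scatter). The change from compound 3 to compound 4, (hydrogen in place of methoxy on an aromatic carbon), is the same change at an identically described place. For compound 4 the step of a number 2 percentage points higher from compound 3 to compound 4 (within the scatter) is expected to stay within the scatter, because no change at the digits printed from compound 1 to compound 2 (within the scatter) on the first core. Compound 4 is therefore estimated at -96%, most likely between -100% and -88% in this assay.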

Compound 4, a percentage reported as activity, at one concentration (the size of the read-out at that concentration, not a potency): -98%
For compound 4 the middle estimate is 2 percentage points above the measured one; low and high end bracket the measured number.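

In this assay hydrogen in place of methoxy on an aromatic carbon gives no change at the digits printed from compound 3 to compound 4 (within the scatter), and this matches the first core: the same change on two cores in this assay, no change at the digits printed (within the scatter) from compound 1 to compound 2 and no change at the digits printed (within the scatter) from compound 3 to compound 4, 0 percentage points apart, within the scatter of two such steps. On these two cores, the change carries over with the same outcome at the one concentration tested. This does not show that the change would leave the read-out unaffected on any other core, and a read-out at a single concentration is not a potency, so any difference that would appear only at lower concentrations stays unseen.

As far as these compounds go, whether a hydroxyl, a fluorine or a longer alkoxy chain on that aromatic carbon would read the same remains open. Also open, from the compounds shown here alone, is whether removing a methoxy group at another place on the ring would behave like this step.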